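Moving the fluorine around the benzyl ring

This account rests on a few compounds, and the source may have more. Where it says the series, first, only, none or still open, it means among the compounds named here.

Measured compounds:
- compound 1, `CCC(C(=O)NCc1ccccc1Cl)N1C(=O)CCC1=O`, 76.4 mg/kg
- compound 2, `CCC(C(=O)NCc1ccccc1F)N1C(=O)CCC1=O`, 65.7 mg/kg

In a functional assay on the whole organism (strain Albino Swiss CD1) with Mus musculus as the target (a lower number here means that less compound is needed, a higher number that more compound is needed for the effect), compound 2 gives the lowest number of the two, but its nearest neighbour, compound 1, sits within the scatter of it: a 1.2-fold lower number from compound 1 to compound 2 (0.07 log units; within the scatter). Compound 3, `CCC(C(=O)NCc1cccc(F)c1)N1C(=O)CCC1=O`, is not yet measured. It differs from compound 2 by 3-fluorophenyl in place of 2-fluorophenyl on a saturated chain carbon bound to an amide-type nitrogen. For the measured compounds named here, no measured step covers this change; the only step known, that from chloro to fluoro, was small and within the scatter. It bears on the present case only in showing that the ring substituent has so far made little difference in this assay. On that basis compound 3 is expected to stay close to compound 2, with a step of a 1.0-fold higher number from compound 2 to compound 3 (0.00 log units; within the scatter), that is, none beyond the scatter. The estimate for compound 3 is therefore 66 mg/kg, in a range from 33 mg/kg to 132 mg/kg.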

Compound 3, dose for half-maximal effect: 47.4 mg/kg
Compound 3: the middle estimate sits 1.4-fold (0.14 log units) above what was measured; the measured number falls inside the stated range.
By their numbers in this assay, from the lowest: compounds 3, 2 and 1 (each within the scatter of the next).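

With 3-fluorophenyl in place of 2-fluorophenyl on a saturated chain carbon bound to an amide-type nitrogen, this assay shows a 1.4-fold lower number from compound 2 to compound 3 (0.14 log units; within the scatter). Taking 3-fluorophenyl in place of 2-chlorophenyl at the same place gives a 1.6-fold lower number from compound 1 to compound 3 (0.21 log units; within the scatter), so a change in where the halogen sits, and not only in which halogen it is, has now been tested here, and compound 1, compound 2 and compound 3 all remain within the scatter of one another. Nothing available accounts for these numbers.

The compounds shown carry only fluoro and chloro on this ring, so they leave open whether any substituent here can produce a step beyond the scatter. A trifluoromethyl group or an amine on the ring could test this.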